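The source may report more compounds than this note shows. Statements on the series, on what has been measured and on what is new or still open speak of the compounds shown alone.

Measured compounds:
- compound 1, `Cc1nn(C)c(-n2cccc2)c1/C=N/OCc1ccc(C(=O)OC(C)(C)C)cc1`, gives 2.48 ug/mL in a functional assay on HCT-15 cells (Homo sapiens) for cytotoxicity; on this read-out lower numbers stand for stronger inhibition and higher numbers for weaker inhibition
- compound 2, `Cc1nn(C)c(-n2ccnc2)c1/C=N/OCc1ccc(C(=O)OC(C)(C)C)cc1`, gives 8.67 ug/mL in this assay
- compound 3, `Cc1nn(C)c(-n2cccn2)c1/C=N/OCc1ccc(C(=O)OC(C)(C)C)cc1`, gives 3.63 ug/mL in this assay

All three share one core and differ only in the group that sits on an aromatic carbon of the five-membered ring with two nitrogen atoms. Compound 3 stands second highest of the three numbers: its nearest neighbour is compound 1, a 1.5-fold higher number from compound 1 to compound 3 (0.17 log units; within the scatter), and its furthest is compound 2, a 2.4-fold lower number from compound 2 to compound 3 (0.38 log units; beyond the scatter).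

Compound 4, `Cc1nn(C)c(N(C)C)c1/C=N/OCc1ccc(C(=O)OC(C)(C)C)cc1`, is not yet measured. It differs from compound 3 in one place: dimethylamino in place of 1H-pyrazol-1-yl on an aromatic carbon. Among the compounds with values here, none of the measured steps exchanges a ring for a group without a ring, so no step bears on this change directly. The exchanges that are known at this place were a 3.5-fold higher number from compound 1 to compound 2 (0.54 log units; beyond the scatter) and a 2.4-fold lower number from compound 2 to compound 3 (0.38 log units; beyond the scatter), while a 1.5-fold higher number from compound 1 to compound 3 (0.17 log units; within the scatter) stayed within the scatter. Swaps at this position have so far moved the number by at most a modest amount.

For compound 4 a modest step is therefore expected, most likely towards a somewhat higher number, so that a 1.4-fold higher number from compound 3 to compound 4 (0.14 log units; within the scatter) is the estimated change. Compound 4 is expected to give 5 ug/mL in this assay, within a range from 1.5 ug/mL to 15 ug/mL.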

Compound 4, half-maximal inhibitory concentration: 6.22 ug/mL
Estimate against measurement, compound 4: 1.2-fold (0.09 log units) below; the measured number falls inside the stated range.
By their numbers in this assay, from the lowest: compounds 1, 3, 4 and 2 (each within the scatter of the next, the first and the last beyond it).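

In this assay, within the data shown here, dimethylamino is the first group at this place that has no ring, yet a 1.7-fold higher number from compound 3 to compound 4 (0.23 log units; within the scatter) and a 1.4-fold lower number from compound 2 to compound 4 (0.14 log units; within the scatter) both stay within the scatter. Only the comparison with the 1H-pyrrol-1-yl group goes beyond it, and only modestly, with a 2.5-fold higher number from compound 1 to compound 4 (0.40 log units; beyond the scatter), so among these four compounds a five-membered aromatic ring at this place is not needed for a number in this range. No measurement available here explains the differences between these groups.

The compounds shown leave open whether other groups without a ring at this place, such as a primary amine or a longer chain like diethylamino, would also stay in this range, and so how much room this position really allows. They also leave open whether the same tolerance would hold if the ester on the shared core were replaced by a carboxylic acid, since every compound here carries the same ester.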